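This account rests on a few compounds, and the source may have more. Where it says the series, first, only, none or still open, it means among the compounds named here.

Within the data shown here, in a functional assay on MV4-11 cells (Homo sapiens) for inhibition, read by resazurin assay, with a stated time of 72 h (on this read-out higher numbers stand for weaker inhibition of growth and lower numbers for stronger inhibition of growth), compound 1 `O=C1NCCC12CCN(c1c(Cl)cncc1-c1cccs1)CC2` gives 480 nM, the lower of the two numbers measured so far, while compound 2 `Cc1ccc(-c2cncc(Cl)c2N2CCC3(CCNC3=O)CC2)o1` gives 4950 nM. Compound 3 `O=C1NCCC12CCN(c1c(Cl)cncc1-c1ccc(CN3CCCCC3)s1)CC2` keeps the core of compound 1 and carries one change: (piperidin-1-yl)methyl in place of hydrogen on an aromatic carbon, with (piperidin-1-yl)methyl in place of hydrogen on an aromatic carbon next to the ring sulfur. Among the measured compounds shown here, only one measured step bears on this, and only indirectly. That step, a 10-fold higher number from compound 1 to compound 2 (1.01 log units; beyond the scatter), is large, but it exchanges thiophen-2-yl for 5-methylfuran-2-yl, so it alters the ring as well as adding a group. For the measured compounds named here, it therefore hints at a possible rise in this assay without fixing its size, and the data hold no direct precedent for the new group. The expected change is modest, an estimated 1.5-fold higher number from compound 1 to compound 3 (0.16 log units; within the scatter). For compound 3 the estimated value is 700 nM, with an expected range from 120 nM to 4000 nM.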

Compound 3, concentration for 50% growth inhibition: 4010 nM
Beside the measured number, compound 3's estimate is 5.7-fold (0.76 log units) below it; the measured number lies above the stated range.
By their numbers in this assay, from the lowest: compound 1; then compounds 3 and 2 (each within the scatter of the next).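

On the five-membered aromatic ring with 1 sulfur, the carbon next to the ring sulfur is now probed without any change to the ring itself. In this assay, placing (piperidin-1-yl)methyl there in place of hydrogen gives an 8.4-fold higher number from compound 1 to compound 3 (0.92 log units; beyond the scatter), so this substitution alone is enough to weaken growth inhibition beyond the scatter, something the earlier step could not show since it also exchanged the ring. Nothing available accounts for this loss.

Still open, from the compounds shown here alone, is whether the loss follows from the piperidine ring, the methylene link or any substituent at this carbon. A simple methyl group, a hydroxymethyl group or an open-chain dimethylaminomethyl group on the same carbon would help to separate these possibilities.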